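Acyl carbamates on the shared core: compound 1 toward compound 3

The source may report more compounds than this note shows. Statements on the series, on what has been measured and on what is new or still open speak of the compounds shown alone.

The shared core is carried by compound 1 `CNC(=O)O[C@@H]1CO[C@]2(COC(C)(C)O2)[C@@](O)(C2(C)CO2)[C@@H]1OC`, by compound 2 `CO[C@@H]1[C@H](OC(=O)NC(=O)CCl)CO[C@]2(COC(C)(C)O2)[C@@]1(O)C1OC1CCCc1ccccc1` and by the as yet unmeasured compound 3 `CO[C@@H]1[C@H](OC(=O)NC(=O)c2ccccc2)CO[C@]2(COC(C)(C)O2)[C@@]1(O)C1(C)CO1`. In a functional assay on A-431 cells (Homo sapiens) for antiproliferative activity (a lower number here means a stronger inhibitor, a higher number a weaker inhibitor), compound 1 reports only a limit of the assay, > 500000 nM. In this assay compound 2 gives 19000 nM; 29000 nM (2 entries) across repeated entries. Compound 3 arises from compound 1 through (benzoyl in place of methyl on an amide-type nitrogen). Among the compounds with values here, no measured step covers this change, so the expectation rests on the two values shown; a move toward stronger inhibition beyond the scatter is expected, an at least 5.0-fold lower number from compound 1 to compound 3 (0.69 log units; beyond the scatter). Compound 3 is estimated at 100000 nM in this assay, with a range from 20000 nM to 500000 nM.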

Compound 3, half-maximal inhibitory concentration: > 500000 nM
Compound 3 was reported as a limit (the forecaster's own chance of this, stated with the estimate: 40%); at least 5.0-fold (0.69 log units) between middle value and limit.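

No step can be read from compound 1 to compound 3, because both values are limits of the assay: the limit of > 500000 nM in this assay, at which 2 of the 3 values shown sit. On these data alone, what benzoyl in place of methyl on an amide-type nitrogen does to antiproliferative activity stays open.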